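Swapping a Benzylamino Group for a Mesylate Ester

A few compounds are considered here, and "the series" means these few. Any claim that something is new, unique, unknown or untested is made for them only; others in the source may bear on it.

This short series of analogues shares one core, seen in compound 2 `O=C(NCc1ccc(F)cc1)c1nc(Br)c2cccnc2c1NCc1ccccc1`, and is examined for how much of each compound growing human cells tolerate. In a toxicity assay on C8166 cells (Homo sapiens) for cytotoxicity, read by MTT assay, with a stated time of 72 h (a lower number here means that less compound is tolerated, a higher number that more compound is tolerated), compound 2 has no single number to report, its entry reading "not determined" (no result reported). Compound 1 `O=C(NCc1ccc(F)cc1)c1nc(Br)c2cccnc2c1NCCCNc1c(C(=O)NCc2ccc(F)cc2)nc(Br)c2cccnc12` is a further entry without a single number, its entry in this assay reading "not determined" (no result reported). Among the compounds with values here, the only measured value belongs to compound 3 `C[C@@H](CO)Nc1nc(C(=O)NCc2ccc(F)cc2)c(O)c2ncccc12`, which in this assay gives 107000 nM. Compound 4 `CS(=O)(=O)Oc1c(C(=O)NCc2ccc(F)cc2)nc(Br)c2cccnc12` is not yet measured. Compared with compound 2, the change in compound 4 is (methylsulfonyl)oxy in place of benzylamino on an aromatic carbon. Within the data shown here, no step between two measured compounds exists here, so there is nothing to anchor the direction or size of the move from compound 2 to compound 4 in this assay; the one value shown, for compound 3, points to a weakly cytotoxic range. Compound 4 is therefore expected to fall near 50000 nM, within a broad range from 10000 nM to 200000 nM, with a fair chance that only a limit is reported.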

Compound 4, half-maximal cytotoxic concentration: 48000 nM
Compound 4: the middle estimate sits 1.0-fold (0.02 log units) above what was measured, within the range that was stated.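

In this assay, within the data shown here, compound 2 has no single number, so no new step to compound 4 can be read. No measured evidence bears on the value of compound 4. The compounds shown leave open how swapping benzylamino for (methylsulfonyl)oxy changes how much compound cells tolerate.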